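Working notes: aryl substituent steps toward compound 4

This account rests on a few compounds, and the source may have more. Where it says the series, first, only, none or still open, it means among the compounds named here.

Measured so far:
compound 1 `CCOC(=O)C1=C(Nc2ccccc2)S/C(=C\c2ccc[nH]2)C1=O` — 49.2%
compound 2 `CCOC(=O)C1=C(Nc2ccc(OC)cc2)S/C(=C\c2ccc[nH]2)C1=O` — 27.6%
compound 3 `CCOC(=O)C1=C(Nc2cccc(F)c2)S/C(=C\c2ccc[nH]2)C1=O` — 45.4%

The read-out is a functional assay on JAR cells (Homo sapiens) for inhibition, read by MTT assay, with a stated time of 72 h, tested at 10 uM; on this read-out higher numbers stand for more inhibition at the one concentration tested (going by the name of the read-out) and lower numbers for less inhibition. Compound 3 stands second highest of the three numbers; against compound 1 it lies within the scatter, a number 3.8 percentage points lower from compound 1 to compound 3 (within the scatter), while the gap to compound 2 is beyond it, a number 17.8 percentage points higher from compound 2 to compound 3 (beyond the scatter). Compound 4 `CCOC(=O)C1=C(Nc2cccc(C(F)(F)F)c2)S/C(=C\c2ccc[nH]2)C1=O` differs from compound 3 by trifluoromethyl in place of fluoro on an aromatic carbon. Among the measured compounds shown here, no measured step exchanges one substituent for another at this place; the nearest guide is that fluoro entering, a number 3.8 percentage points lower from compound 1 to compound 3 (within the scatter), stayed within the scatter, whereas methoxy entering, a number 21.6 percentage points lower from compound 1 to compound 2 (beyond the scatter), cost beyond it. For compound 4 the expected step is therefore a number 3.4 percentage points lower from compound 3 to compound 4 (within the scatter), not beyond the scatter. Compound 4 is estimated at 42% in this assay, range 25% to 58%.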

Compound 4, a percentage reported as inhibition, at one concentration (the size of the read-out at that concentration, not a potency): 52.9%
Compound 4: middle estimate off by 10.9 percentage points, on the low side; measured number inside the range.
By their numbers in this assay, from the lowest: compound 2; then compounds 3, 1 and 4 (each within the scatter of the next).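

Trifluoromethyl in place of fluoro gives a number 7.5 percentage points higher from compound 3 to compound 4 (within the scatter), and trifluoromethyl in place of hydrogen gives a number 3.7 percentage points higher from compound 1 to compound 4 (within the scatter). Among the compounds shown here, this is the first exchange of one substituent for another at this place, and going from one heavy atom to four, meta to a large group, moves the number by no more than the scatter. Nothing on hand explains why the number holds here.

As far as these compounds go, whether an amine or a carboxylic acid at this place would keep the number stays open. Also open, from the compounds shown here alone, is how trifluoromethyl would fare at the place that methoxy occupies in compound 2.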